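The source may report more compounds than this note shows. Statements on the series, on what has been measured and on what is new or still open speak of the compounds shown alone.

Within the data shown here, in a functional assay on MCF7 cells (Homo sapiens) for inhibition, read by MTT assay, with a stated time of 72 h (on this read-out lower numbers stand for stronger inhibition and higher numbers for weaker inhibition), compound 1 `Nc1ncnc2c1c(-c1cnc3[nH]ccc3c1)nn2CCCCCCCCC(=O)NO` gives 24700 nM, the only actual number so far. Compound 2 `Nc1nc2cc(-c3nn(CCCC(=O)NO)c4ncnc(N)c34)ccc2o1` reads > 50000 nM, which is a limit of the assay. Compound 3 `Nc1ncnc2c1c(-c1cnc3[nH]ccc3c1)nn2CCCCC(=O)NO` reads > 150000 nM, which is also a limit of the assay.

The next analogue, compound 4 `Nc1ncnc2c1c(-c1cnc3[nH]ccc3c1)nn2CCCCCCCCCC(=O)NO`, lengthens the chain of compound 1: (hydroxycarbamoyl)methyl in place of hydroxycarbamoyl on a saturated chain carbon, eight bonds along the chain from an aromatic nitrogen. This places (hydroxycarbamoyl)methyl in place of hydroxycarbamoyl on a saturated chain carbon, eight bonds along the chain from an aromatic nitrogen.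

Among the measured compounds shown here, one measured step bears on this change: hydroxycarbamoyl in place of 4-(hydroxycarbamoyl)butyl, an at least 6.0-fold higher number from compound 1 to compound 3 (0.78 log units; beyond the scatter). That step lies beyond the scatter, and one end of it is a limit. It runs in the shortening sense and removes a much longer piece of chain than compound 4 adds. Compound 2 differs from compound 1 in more than one place, so it gives no clean comparison. On these data alone, a single step fixes no trend, so the sign of the lengthening effect remains open.

The expected change is small, a 1.1-fold lower number from compound 1 to compound 4 (0.05 log units; within the scatter), and is not expected to exceed the scatter. Compound 4 is estimated at 22000 nM, with an expected range of 8000 nM to 60000 nM.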

Compound 4, half-maximal inhibitory concentration: 23200 nM
Estimate against measurement, compound 4: 1.1-fold (0.02 log units) below, within the range that was stated.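

In this assay, among these compounds, putting (hydroxycarbamoyl)methyl in place of hydroxycarbamoyl at this position, on a saturated chain carbon, eight bonds along the chain from an aromatic nitrogen, gives the first step between two actual numbers, and it stays within the scatter: a 1.1-fold lower number from compound 1 to compound 4 (0.03 log units; within the scatter). Compound 1 and compound 4 therefore read alike at the long-chain end, while the short-chain compound 3 stands apart from compound 4, beyond the scatter: an at least 6.4-fold lower number from compound 3 to compound 4 (0.81 log units; beyond the scatter). The reading of compound 3 is a limit of the assay, so that step gives only a minimum size and says nothing of the true gap: the limit of > 150000 nM in this assay, at which 1 of the 4 values shown sits.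

The compounds shown leave open where, between the chain of compound 3 and the chain of compound 1, the read-out changes, and whether a longer chain than that of compound 4 would stay within the scatter of compound 4. They also leave open whether a carboxylic acid or a primary amide at the chain end, in place of the hydroxycarbamoyl group, would keep the reading of compound 4.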